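This account rests on a few compounds, and the source may have more. Where it says the series, first, only, none or still open, it means among the compounds named here.

Of the compounds shown here, three have so far been measured in a functional assay on NCI-H23 cells (Homo sapiens) for cytotoxicity, read by sulforhodamine B assay, with a stated time of 48 h, tested at 100 uM; on this read-out lower numbers stand for a stronger effect and higher numbers for a weaker effect at the one concentration tested. Compound 1 `COc1cc(-c2cc(/C=C/C(=O)c3ccc(N)cc3)[nH]n2)cc(OC)c1OC` gives -55%, and compound 2 `COc1ccc(-c2cc(/C=C/C(=O)c3cc(OC)c(OC)c(OC)c3)[nH]n2)cc1OC` gives -50%. Compound 3 `COc1ccc(C(=O)/C=C/c2cc(-c3cc(OC)c(OC)c(OC)c3)n[nH]2)cc1` gives -23%, the highest of the three numbers and so the weakest effect seen here; compound 2 lies closest to it and compound 1 furthest. For the measured compounds named here, the one step whose two members differ in a single place runs a number 32 percentage points higher from compound 1 to compound 3 (beyond the scatter), a methoxy in place of an amino on an aromatic carbon.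

Compound 4 `COc1cc(-c2cc(/C=C/C(=O)c3ccc(F)c(F)c3)[nH]n2)cc(OC)c1OC` has not yet been measured. It differs from compound 3 in one place: 3,4-difluorophenyl in place of 4-methoxyphenyl on a carbonyl carbon. Going by the values given here, the measured step exchanged one group on this same ring, but both of its groups carry oxygen or nitrogen, and nothing measured here involves a fluorine-bearing ring, so no measured step bears directly on this change. Among the compounds with values here, the only guidance is that compound 1 with -55% and compound 2 with -50% sit well below compound 3, which suggests that the weaker effect of compound 3 is not fixed for this series. The step from compound 3 to compound 4 is therefore estimated as a number 9 percentage points lower from compound 3 to compound 4 (within the scatter), modest and downward, close to the scatter. Compound 4 is expected to give -32%, within a range from -62% to -2%.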

Compound 4, a percentage reported as activity, at one concentration (the size of the read-out at that concentration, not a potency): -27%
Compound 4: the middle estimate sits 5 percentage points below what was measured, and the stated range covers the measured number.
By their numbers in this assay, from the lowest: compounds 1 and 2 (each within the scatter of the next); then compounds 4 and 3 (each within the scatter of the next).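

In this assay, the change on the carbonyl carbon gives a number 4 percentage points lower from compound 3 to compound 4 (within the scatter) once 3,4-difluorophenyl replaces 4-methoxyphenyl, so a ring bearing fluorine instead of oxygen cannot be told apart from the earlier ring at this position. The same ring in place of 4-aminophenyl gives a number 28 percentage points higher from compound 1 to compound 4 (beyond the scatter) and so repeats the direction of the earlier a number 32 percentage points higher from compound 1 to compound 3 (beyond the scatter), which means two different replacements of the amino-bearing ring both end with a weaker effect. Among these three compounds, which differ only in this ring, compound 1 therefore stands apart while compound 3 and compound 4 sit together, and no available evidence accounts for this difference.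

On these data alone, what remains open is whether the stronger effect of compound 1 is specific to the amino group, which a 4-(dimethylamino)phenyl or 4-hydroxyphenyl ring at the same place could help to show. As far as these compounds go, it is also open whether one fluorine alone, as in 4-fluorophenyl, would sit with compound 3 and compound 4, or whether a ring bearing a carboxylic acid would depart from them.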